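The source may hold more compounds than are shown below. What is called first, only, known or untested is meant among the compounds shown, and "the series" means these compounds.

Measured in a physicochemical assay for solubility, with a stated time of 3 days, at pH 7; on this read-out lower numbers stand for lower solubility and higher numbers for higher solubility:
- compound 1 `CN1CCC(Oc2ccc(-c3nc4cc(C(N)=O)ccc4[nH]3)cc2)CC1`: > 400000 nM (a limit of the assay, not a number)
- compound 2 `Cc1ccc(CN2CCC(COc3ccc(-c4nc5cc(C(N)=O)ccc5[nH]4)cc3)CC2)cc1`: "not determined" (no result reported)
- compound 3 `NC(=O)c1ccc2[nH]c(-c3ccc(OCCC4CCN(Cc5ccccc5)CC4)cc3)nc2c1`: 5000 nM

Of these three entries, only compound 3 has an actual number, 5000 nM. Compound 2 has no result, and compound 1 has only a limit, so compound 3 is the one firm reference point, and it sits on the low side of that limit.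

The next compound to be tested is compound 4 `CC(=O)N1CCC(CCOc2ccc(-c3nc4cc(C(N)=O)ccc4[nH]3)cc2)CC1`. It has acetyl in place of benzyl on an amine nitrogen in a ring. Everything else matches compound 3, and the change removes the aromatic ring of the benzyl group.

Among the compounds with values here, no measured pair isolates this change, so any forecast is tentative. It leans on compound 1, which has no benzyl either and whose entry of > 400000 nM is a limit. In this assay, the expected step of a 10-fold higher number from compound 3 to compound 4 (1.00 log units; beyond the scatter) is a rise beyond the usual scatter. For compound 4, the estimated value is 50000 nM, with an expected range of 10000 nM to 250000 nM.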

Compound 4, solubility: 2000 nM
Compound 4: the middle estimate sits 25-fold (1.40 log units) above what was measured; measured number below the stated range.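

Within this assay, acetyl in place of benzyl on an amine nitrogen in a ring gives a 2.5-fold lower number from compound 3 to compound 4 (0.40 log units; beyond the scatter), the only measured step at this position. Losing the aromatic ring and going from 7 heavy atoms to 3 therefore did not raise the number here; it moved modestly the other way. Compound 1 still offers only a limit, not a number, so it gives no firm comparison: the limit of > 400000 nM in this assay, at which 1 of the 4 values shown sits.

This single step cannot separate the loss of the aromatic ring from the arrival of the acetyl carbonyl. A benzoyl group on the same nitrogen, which carries both an aromatic ring and a carbonyl, or a sulfonyl group there, would be needed to tell how much each part of the change counts.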